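The source may hold more compounds than are shown below. What is called first, only, known or untested is meant among the compounds shown, and "the series" means these compounds.

Of the compounds shown here, two have so far been measured in an assay on HEK293 cells for inhibition of 17-beta-hydroxysteroid dehydrogenase type 1 (Mus musculus), read by HPLC, tested at 500 nM, in the presence of a further agent that is not named here; on this read-out higher numbers stand for more inhibition at the one concentration tested (going by the name of the read-out) and lower numbers for less inhibition. Compound 1 `Cc1cccc(S(=O)(=O)Nc2cccc(-c3ccc(C(=O)c4cc(F)c(F)c(O)c4F)s3)c2)c1` gives 49% in this assay. Compound 2 `O=C(c1ccc(-c2cccc(NS(=O)(=O)c3ccccc3)c2)s1)c1c(F)ccc(O)c1Cl` gives 25%, the lower of the two numbers, and its gap to compound 1 lies beyond the usual scatter. The next compound, compound 3 `O=C(c1ccc(-c2cccc(NS(=O)(=O)c3ccccc3)c2)s1)c1cccc(O)c1Cl`, differs from compound 2 in a single place: hydrogen in place of fluoro on an aromatic carbon. Within the data shown here, no step between measured compounds resembles this change, so its size cannot be read from the data. The change is expected to shift the read-out by a number 5 percentage points lower from compound 2 to compound 3 (within the scatter), a step within the scatter. Compound 3 is therefore estimated at 20%, with a range from 5% to 38%.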

Compound 3, a percentage reported as inhibition, at one concentration (the size of the read-out at that concentration, not a potency): 26%
The estimate for compound 3 lay 6 percentage points below the measured number; measured number inside the range.
By their numbers in this assay, from the lowest: compounds 2 and 3 (each within the scatter of the next); then compound 1.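

Taking fluoro off the 2-chloro-6-fluoro-3-hydroxyphenyl group and putting hydrogen in its place gives a step of a number 1 percentage points higher from compound 2 to compound 3 (within the scatter) in this assay. At this position, ortho to a large group, this read-out therefore does not tell fluoro and hydrogen apart in this setting. Nothing at hand gives a reason for this result. Going by these compounds, whether a larger group here, such as methoxy or an amine, would read the same remains open. So does whether fluoro and hydrogen would also match with other groups on this ring.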